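A few compounds are considered here, and "the series" means these few. Any claim that something is new, unique, unknown or untested is made for them only; others in the source may bear on it.

Measured compounds:
Compound 1, `COc1cc(-c2cc(/C=C/C(=O)c3ccc(N)cc3)[nH]n2)cc(OC)c1OC`: 4520 nM
Compound 2, `COc1ccc(C(=O)/C=C/c2cc(-c3cc(OC)c(OC)c(OC)c3)n[nH]2)cc1OC`: 3130 nM

In a functional assay on SN12C cells (Homo sapiens) for inhibition, read by sulforhodamine B assay, with a stated time of 48 h (a lower number here means a stronger inhibitor of growth, a higher number a weaker inhibitor of growth), compound 1 gives 4520 nM, and compound 2 gives 3130 nM. Compound 2 carries the lower of the two numbers, but the distance between them is a 1.4-fold lower number from compound 1 to compound 2 (0.16 log units; within the scatter), so the two values show no real separation in this assay and neither compound can be ranked above the other.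

Compound 3, `COc1cc(C(=O)/C=C/c2cc(-c3cc(OC)c(OC)c(OC)c3)n[nH]2)cc(OC)c1OC`, has not yet been measured. It differs from compound 2 by methoxy in place of hydrogen on an aromatic carbon. Going by the values given here, the only measured step that touches this part of the molecule is the exchange of 4-aminophenyl for 3,4-dimethoxyphenyl on a carbonyl carbon, which moved the number only by a 1.4-fold lower number from compound 1 to compound 2 (0.16 log units; within the scatter). A further methoxy on that same ring therefore gives no grounds to expect a shift beyond the scatter in this assay, in either direction.

Compound 3 is expected to give 3000 nM, with a range of 1500 nM to 6500 nM. The expected step is a 1.0-fold lower number from compound 2 to compound 3 (0.02 log units; within the scatter).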

Compound 3, concentration for total growth inhibition: 2970 nM
Compound 3: middle estimate off by 1.0-fold (0.00 log units), on the high side; the measured number falls inside the stated range.
By their numbers in this assay, from the lowest: compounds 3, 2 and 1 (each within the scatter of the next).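

In this assay, the step is a 1.1-fold lower number from compound 2 to compound 3 (0.02 log units; within the scatter), with methoxy in place of hydrogen on an aromatic carbon, ortho to a methoxy group and meta to a large group. The earlier step, a 1.4-fold lower number from compound 1 to compound 2 (0.16 log units; within the scatter), exchanged the whole 4-aminophenyl group for 3,4-dimethoxyphenyl on a carbonyl carbon, so it could not speak for a single site on that ring, whereas this step isolates one position and shows that a methoxy group there leaves compound 3 without any real separation from compound 2. This tells only that methoxy and hydrogen cannot be told apart at this position in this assay, and no measurement shown here offers an explanation for that result.

The compounds shown leave open whether a different group at this position, such as a hydroxy group, an amine, a fluorine atom or a longer chain like ethoxy, would give a number separated from that of compound 2. They also leave open whether the same lack of separation would hold for a methoxy group placed elsewhere on the shared core.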